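Inverting the chain stereocentre of compound 1

The compounds below may be only part of what the source reports. "The series", "measured", "known", "first", "only" and "open" are said of these compounds alone.

Measured values in an ADME assay on the whole organism for inhibition, with Oryza sativa as the target, with a stated time of 4 days (on this read-out lower numbers stand for stronger inhibition and higher numbers for weaker inhibition), so far:
- compound 1 `CC[C@H](C)Nc1nc(Cl)nc(N[C@@H](C)c2ccccc2)n1` gives 6920 nM
- compound 2 `CNc1nc(Cl)nc(N[C@H](C)c2ccccc2)n1` gives 22400 nM
- compound 3 `CC(C)Nc1nc(Cl)nc(N[C@H](C)c2ccccc2)n1` gives 5370 nM

Compound 1 lies within the scatter of compound 3 and, beyond the scatter, under compound 2, which has the highest number of the three. The next compound to be read is compound 4 `CC[C@@H](C)Nc1nc(Cl)nc(N[C@@H](C)c2ccccc2)n1` and its relation to compound 1 is simple: the two compounds have the same atoms and bonds and differ only in configuration as drawn: 1 of 2 stereo elements differ; a stereocentre at a saturated chain carbon is drawn S in compound 1 and R in compound 4 and the drawing holds no other difference.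

For the measured compounds named here, only one measured step links compounds that differ in one place: a 4.2-fold lower number from compound 2 to compound 3 (0.62 log units; beyond the scatter) for isopropyl in place of methyl on a nitrogen on an aromatic ring. That step is modest and swaps a group, not a configuration, so it sets neither size nor direction here. Going by the values given here, no measured pair differs in configuration alone. The expectation in this assay therefore stays with compound 1 at 6920 nM with no step beyond the scatter expected and no direction favoured. The estimated step is a 1.0-fold higher number from compound 1 to compound 4 (0.00 log units; within the scatter) and this remains an expectation without direct precedent. For compound 4 the estimated value is 7000 nM and it is expected to fall from 3000 nM to 16000 nM as a working range.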

Compound 4, half-maximal inhibitory concentration: 9770 nM
For compound 4 the middle estimate is 1.4-fold (0.14 log units) below the measured one, within the range that was stated.
By their numbers in this assay, from the lowest: compounds 3, 1 and 4 (each within the scatter of the next); then compound 2.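

In this assay, inverting the saturated chain carbon gives a 1.4-fold higher number from compound 1 to compound 4 (0.15 log units; within the scatter), so at this position the two drawn configurations are not separated by the read-out. The earlier step, a 4.2-fold lower number from compound 2 to compound 3 (0.62 log units; beyond the scatter), exchanged one group for another on a nitrogen and lies beyond the scatter, whereas this comparison isolates configuration at the chain stereocentre, and it can be read that way because no other feature changes: the fact that compounds 1 and 4 differ only in the configuration as drawn. For this pair, the inversion therefore gives a much smaller step than the group exchange did, though the two steps come from different compounds and different kinds of change.

As far as these compounds go, it remains open whether the second stereocentre, the one carrying the phenyl-bearing chain, would prove equally insensitive to inversion, and whether the result for compound 1 and compound 4 would hold with that centre drawn the other way. From the compounds shown here alone, it is also open whether a stereocentre in a longer chain, such as a 2-hexyl group on the same nitrogen, would separate its two configurations in this assay.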